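Ethyl for methyl on the amine of two related cores

The compounds below may be only part of what the source reports. "The series", "measured", "known", "first", "only" and "open" are said of these compounds alone.

Measured so far:
compound 1 `CNCC(=O)Nc1cc(OC)ccc1C(=O)c1ccc(OC)c2c1C=CC(C)(C)O2` gives 3460 nM in a functional assay on HCT-8 cells (Homo sapiens) for antiproliferative activity, read by MTT assay, with a stated time of 48 h; a higher number here means a weaker inhibitor, a lower number a stronger inhibitor.
compound 2 `CCNCC(=O)Nc1cc(OC)ccc1C(=O)c1ccc(OC)c2c1C=CC(C)(C)O2` gives 7890 nM in this assay.
compound 3 `C=C(c1ccc(OC)cc1NC(=O)CNC)c1ccc(OC)c2c1C=CC(C)(C)O2` gives 980 nM in this assay.

Compound 3 has the lowest number of the three, and its steps to compound 1 and to compound 2 are both beyond the scatter. How the core of compound 3 differs from the core of compound 1 is not broken down here.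

Compound 1 and compound 2 differ in one place, (methyl in place of hydrogen on a saturated chain carbon bound to an amine nitrogen). That change gave a 2.3-fold higher number from compound 1 to compound 2 (0.36 log units; beyond the scatter).

Compound 4 `C=C(c1ccc(OC)cc1NC(=O)CNCC)c1ccc(OC)c2c1C=CC(C)(C)O2` is not yet measured. Among the compounds with values here, it differs from compound 3 by methyl in place of hydrogen on a saturated chain carbon bound to an amine nitrogen, which is the same change, at the same kind of place, as the one from compound 1 to compound 2.

Because a 2.3-fold higher number from compound 1 to compound 2 (0.36 log units; beyond the scatter) was modest but beyond the scatter, a step of similar size is expected from compound 3 to compound 4, namely a 2.1-fold higher number from compound 3 to compound 4 (0.33 log units; beyond the scatter). This rests on a single measured pair, so the expectation is held loosely. For compound 4 the estimate in this assay is 2100 nM, with a range from 1000 nM to 4500 nM.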

Compound 4, half-maximal inhibitory concentration: 3050 nM
Compound 4: middle estimate off by 1.5-fold (0.16 log units), on the low side, and the stated range covers the measured number.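

In this assay, the change from methylamino to ethylamino on the second core gave a 3.1-fold higher number from compound 3 to compound 4 (0.49 log units; beyond the scatter). Set beside the step on the first core, it ran in the same direction, and the two steps cannot be told apart in size: the same change on two cores in this assay, a 2.3-fold higher number (0.36 log units; beyond the scatter) from compound 1 to compound 2 and a 3.1-fold higher number (0.49 log units; beyond the scatter) from compound 3 to compound 4, 1.4-fold (0.14 log units) apart, within the scatter of two such steps This shows that, across these two cores, the change carried over in this assay, but it rests on only two pairs and does not show that the same step would hold on any other core, or why the number rises.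

The compounds shown leave open how far this trend runs along the amine: a propyl chain or a longer chain in place of ethyl might continue the rise or might not. They also leave open what a primary amine or a tertiary dimethylamino group would give at the same place on either core.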